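Swapping a Branched Ester Group for a Thiophene-Bearing One

This account rests on a few compounds, and the source may have more. Where it says the series, first, only, none or still open, it means among the compounds named here.

In a functional assay on NCI-H460 cells (Homo sapiens) for cytotoxicity, read by MTT assay, with a stated time of 48 h (a lower number here means a stronger inhibitor, a higher number a weaker inhibitor), compound 1 (`C=C1C(=O)O[C@H]2CC3=C[C@H](C/C(C)=C/[C@@H](OC(=O)CC4CCCCC4)[C@H]12)OC3=O`) gives 2000 nM and compound 2 (`C=C1C(=O)O[C@H]2CC3=C[C@H](C/C(C)=C/[C@@H](OC(=O)C(C)(C)CC)[C@H]12)OC3=O`) gives 6100 nM, the higher of the two numbers. Among the measured compounds shown here, the only measured step, a 3.1-fold higher number from compound 1 to compound 2 (0.48 log units; beyond the scatter), is modest and beyond the scatter; it exchanges cyclohexylmethyl for 1,1-dimethylpropyl on a carbonyl carbon. Compound 3 (`C=C1C(=O)O[C@H]2CC3=C[C@H](C/C(C)=C/[C@@H](OC(=O)/C=C/c4cccs4)[C@H]12)OC3=O`) keeps the shared core and changes that same place, with 2-(thiophen-2-yl)ethenyl in place of 1,1-dimethylpropyl on a carbonyl carbon. For the measured compounds named here, no measured compound carries a thiophene or this double bond, so the step from compound 1 is only a rough guide to size. Compound 2 stands at the high end of a very short series, so a modest move downward in this assay is expected. The expected change is a 2.0-fold lower number from compound 2 to compound 3 (0.31 log units; beyond the scatter). For compound 3 the estimated value is 3000 nM, with an expected range of 1100 nM to 7500 nM.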

Compound 3, half-maximal inhibitory concentration: 2900 nM
Estimate against measurement, compound 3: 1.0-fold (0.01 log units) above; the measured number falls inside the stated range.
By their numbers in this assay, from the lowest: compounds 1 and 3 (each within the scatter of the next); then compound 2.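

In this assay, the step of a 2.1-fold lower number from compound 2 to compound 3 (0.32 log units; beyond the scatter) shows that this place on the carbonyl carbon accepts a group with a five-membered aromatic ring and a double bond outside it, and that the number moves down when this group replaces 1,1-dimethylpropyl. The step of a 1.5-fold higher number from compound 1 to compound 3 (0.16 log units; within the scatter) lies within the scatter, so 2-(thiophen-2-yl)ethenyl and cyclohexylmethyl cannot be told apart here, and among these three compounds the two groups carrying a ring both give lower numbers than the open-chain group. Nothing available here accounts for these differences.

The compounds shown do not separate the effect of the thiophene ring from that of the double bond that carries it. From the compounds shown here alone, how a phenyl ring at this place, or a chain ending in an amine, would read in this assay remains open.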